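This account rests on a few compounds, and the source may have more. Where it says the series, first, only, none or still open, it means among the compounds named here.

Working notes on the series. Compound 1 `COc1ccc(Oc2ccccc2-c2ccsc2S(=O)(=O)N2CCN(C(=S)Nc3cc(C(F)(F)F)cc(C(F)(F)F)c3)CC2)cc1OC` reads in a functional assay on HeLa cells (Homo sapiens) for inhibition, read by CCK-8 assay, with a stated time of 48 h (on this read-out lower numbers stand for stronger inhibition and higher numbers for weaker inhibition), only as a limit, > 50000 nM. Compound 2 `O=S(=O)(c1sccc1-c1ccccc1Oc1ccc(O)c(O)c1)N1CCN(C(=S)Nc2cc(C(F)(F)F)cc(C(F)(F)F)c2)CC1` also reads in this assay only as a limit, > 20000 nM, so it offers no exact number to start from.

Within the data shown here, the one measured step is a step that the two limits leave unreadable from compound 1 to compound 2, with 3,4-dihydroxyphenyl in place of 3,4-dimethoxyphenyl on an oxygen on an aromatic ring. That step has no readable size and concerns a different place from the next change.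

Compound 3 `O=[N+]([O-])c1ccc(Oc2ccc(O)c(O)c2)c(-c2ccsc2S(=O)(=O)N2CCN(C(=S)Nc3cc(C(F)(F)F)cc(C(F)(F)F)c3)CC2)c1` carries nitro in place of hydrogen on an aromatic carbon, para to a 3,4-dihydroxyphenoxy group. Among the measured compounds shown here, no measured step covers a nitro group, so no size can be carried over to this change. With no measured number in the series, no shift beyond the scatter is expected in either direction, and compound 3 may also read only as a limit.

The expected change is a step that the limit leaves unreadable from compound 2 to compound 3. The estimate for compound 3 is 30000 nM, with an expected range of 8000 nM to 100000 nM.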

Compound 3, half-maximal inhibitory concentration: > 20000 nM
Compound 3 gave a limit, no number (the forecaster's own chance of this, stated with the estimate: 60%); the middle value does not contradict the limit.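

Neither compound 2 nor compound 3 gives a number in this assay; both read only as limits, so the step between them cannot be read. The compounds shown leave open how strongly any of them inhibits, and whether nitro in place of hydrogen on an aromatic carbon shifts the read-out at all.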